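Series notes: 2-methylphenyl to 3-methylphenyl on the shared core

The compounds below may be only part of what the source reports. "The series", "measured", "known", "first", "only" and "open" are said of these compounds alone.

In a physicochemical assay for solubility, with a stated time of 24 h, tested at 30 mg/mL (on this read-out lower numbers stand for lower solubility and higher numbers for higher solubility), compound 1 `O=C(CCCCCNc1c(Nc2ccccc2)c(=O)c1=O)NO` gives 2200000 nM while compound 2 `O=C(CCCCCNc1c(NC2CCCCC2)c(=O)c1=O)NO` gives 8700000 nM and compound 3 `Cc1ccccc1Nc1c(NCCCCCC(=O)NO)c(=O)c1=O` gives 12000000 nM as the starting point. Compound 3 sits at the upper end of these numbers alongside compound 2, with a 1.4-fold higher number from compound 2 to compound 3 (0.14 log units; within the scatter) as the record, and clear of compound 1, with a 5.5-fold higher number from compound 1 to compound 3 (0.74 log units; beyond the scatter) as the record.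

Compound 4 `Cc1cccc(Nc2c(NCCCCCC(=O)NO)c(=O)c2=O)c1` carries 3-methylphenyl in place of 2-methylphenyl on a nitrogen on an aromatic ring, with 3-methylphenyl in place of 2-methylphenyl on a nitrogen on an aromatic ring as the count. Within the data shown here, no measured step moves a methyl group, so the evidence is indirect. The nearest guide is a 5.5-fold higher number from compound 1 to compound 3 (0.74 log units; beyond the scatter) as the methyl group arrives, and a 4.0-fold higher number from compound 1 to compound 2 (0.60 log units; beyond the scatter) is the other modest step at that place. Nothing shows that the gain seen in compound 3 survives the move, so a partial return towards compound 1 is expected, of a size that may not clear the scatter. The expected step is a 1.8-fold lower number from compound 3 to compound 4 (0.27 log units; within the scatter) as a working figure. For compound 4 the estimated value is 6500000 nM with an expected range from 2500000 nM to 14000000 nM as the working estimate.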

Compound 4, solubility: 11000000 nM
For compound 4 the middle estimate is 1.7-fold (0.23 log units) below the measured one; the range from low to high includes it.
By their numbers in this assay, from the lowest: compound 1; then compounds 2, 4 and 3 (each within the scatter of the next).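

Moving the methyl group gives a 1.1-fold lower number from compound 3 to compound 4 (0.04 log units; within the scatter) in this assay, so the 2-methylphenyl and 3-methylphenyl compounds cannot be told apart on this read-out, and a 1.3-fold higher number from compound 2 to compound 4 (0.10 log units; within the scatter) puts compound 4 within the scatter of the cyclohexyl compound as well. The rise over the phenyl compound now rests on two placements of the methyl group, since a 5.0-fold higher number from compound 1 to compound 4 (0.70 log units; beyond the scatter) stands alongside a 5.5-fold higher number from compound 1 to compound 3 (0.74 log units; beyond the scatter) and the result no longer depends on compound 3 alone. Nothing measured here accounts for these numbers.

On these data alone, it remains open whether this rise is particular to a methyl group or would persist with an amine or a carboxylic acid in its place on the aromatic ring. As far as these compounds go, whether a longer chain on the shared core would alter the picture is equally open.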